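Removing bromo from a weakly cytotoxic tetracyclic triazole series

The compounds below may be only part of what the source reports. "The series", "measured", "known", "first", "only" and "open" are said of these compounds alone.

Measured compounds:
compound 1 `C=C1C[C@]23C[C@@]1(O)CC[C@H]2c1cc(Br)c(O)c(C)c1[C@@H]3Cn1cc(-c2ccc(OC)cc2)nn1` — > 20000 nM
compound 2 `C=C1C[C@]23C[C@@]1(O)CC[C@H]2c1ccc(O)c(C)c1[C@@H]3Cn1cc(-c2ccc(OC)cc2)nn1` — > 20000 nM
compound 3 `C=C1C[C@]23C[C@@]1(O)CC[C@H]2c1cc(Br)c(O)c(C)c1[C@@H]3Cn1cc(-c2ccc(Cl)cc2)nn1` — 18000 nM

The three measured compounds share a core and differ in two places. In a functional assay on SW480 cells (Homo sapiens) for cytotoxicity, read by MTT assay, with a stated time of 4 days (on this read-out higher numbers stand for weaker inhibition and lower numbers for stronger inhibition), compound 1 reaches only a limit, > 20000 nM, and not a number. In this assay compound 2 likewise gives only the limit > 20000 nM. Compound 3 is the only one of the three with a number, 18000 nM.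

Compound 2 differs from compound 1 in one change, (hydrogen in place of bromo on an aromatic carbon). The step that the two limits leave unreadable from compound 1 to compound 2 cannot be sized because both values sit at the limit of > 20000 nM in this assay, at which 2 of the 3 values shown sit. Compound 3 differs from compound 1 in the aryl substituent, (chloro in place of methoxy on an aromatic carbon); the step of an at least 1.1-fold lower number from compound 1 to compound 3 (0.04 log units; that floor lies within the scatter) is no more than the floor set by that limit.

Compound 4, `C=C1C[C@]23C[C@@]1(O)CC[C@H]2c1ccc(O)c(C)c1[C@@H]3Cn1cc(-c2ccc(Cl)cc2)nn1`, is not yet measured. It differs from compound 3 by hydrogen in place of bromo on an aromatic carbon, the same change that separates compound 1 from compound 2, made at a place described in the same words. That earlier step is unreadable, so it gives no size to lean on; what remains is that compound 3 itself gives 18000 nM. Compound 4 is therefore expected to show a step of a 1.4-fold higher number from compound 3 to compound 4 (0.14 log units; within the scatter), with a fair chance that this assay reports only a limit. The estimate for compound 4 in this assay is 25000 nM, expected to lie between 12000 nM and 60000 nM.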

Compound 4, half-maximal inhibitory concentration: > 20000 nM
Compound 4: only a limit was reported; the forecaster's own chance of this, stated with the estimate: 60%; the middle value lies beyond the limit too.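

In this assay compound 4 reaches only a limit, > 20000 nM, and not a number. Carried over to the compounds with the chloro aryl substituent, hydrogen in place of bromo on an aromatic carbon gives an at least 1.1-fold higher number from compound 3 to compound 4 (0.04 log units; that floor lies within the scatter), so this step is known only as a floor and does not show that removing bromo changes the read-out by any real amount on either core. The same change between the compounds with the methoxy aryl substituent and the step between the two compounds without bromo cannot be read, and the size of the change therefore cannot be compared from one setting to the other, because these values run into the same limit: the limit of > 20000 nM in this assay, at which 3 of the 4 values shown sit.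

The compounds shown leave open whether any group at this aromatic carbon, ortho to the hydroxy group, would give a number clearly away from that limit, since only bromo and hydrogen appear there. They also leave open what an amine or a carboxylic acid on the aryl ring in place of chloro or methoxy would do, or a longer chain in place of the methyl group, in this cell read-out.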